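Two methyls on the pendant ring: compound 4 expected

The source may hold more compounds than are shown below. What is called first, only, known or untested is meant among the compounds shown, and "the series" means these compounds.

Measured so far:
- compound 1, `O=C(O)C[C@H](O)C[C@H](O)CCn1c(C(F)(F)F)nc(-c2ccc(F)cc2)c1-c1ccc(F)cc1`, in an assay on microsomes from liver for inhibition of 3-hydroxy-3-methylglutaryl-coenzyme A reductase (Rattus norvegicus) (on this read-out higher numbers stand for weaker inhibition and lower numbers for stronger inhibition), compound 1 gives 38 nM
- compound 2, `O=C(O)C[C@H](O)C[C@H](O)CCn1c(C(F)(F)F)nc(-c2ccc(F)cc2)c1-c1cccc(Cl)c1`, in this assay compound 2 gives 41 nM
- compound 3, `Cc1ccc(-c2c(-c3ccc(F)cc3)nc(C(F)(F)F)n2CC[C@@H](O)C[C@@H](O)CC(=O)O)cc1`, in this assay compound 3 gives 750 nM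

Compound 3 gives the highest number of the three, that is the weakest inhibition. Its nearest neighbour is compound 2, and the gap between them is large, as is the gap to compound 1. Both steps that lead to compound 3 swap the aryl group on the shared core: a 20-fold higher number from compound 1 to compound 3 (1.30 log units; beyond the scatter) and an 18-fold higher number from compound 2 to compound 3 (1.26 log units; beyond the scatter). Against that, the step of a 1.1-fold higher number from compound 1 to compound 2 (0.03 log units; within the scatter) shows that the 4-fluorophenyl and 3-chlorophenyl groups give numbers that cannot be told apart.

Compound 4, `Cc1cc(C)cc(-c2c(-c3ccc(F)cc3)nc(C(F)(F)F)n2CC[C@@H](O)C[C@@H](O)CC(=O)O)c1`, has not been measured. It differs from compound 3 in one place: 3,5-dimethylphenyl in place of 4-methylphenyl on an aromatic carbon. The measured steps bear on it only indirectly. Compound 2 shows that a group on the ring carbon named in "3-chlorophenyl" is tolerated, while compound 3 shows that the 4-methylphenyl pattern is not. Going by the values given here, no measured compound carries two methyls, so the direction is uncertain; a moderate drop in the number is expected, though it may stay within the scatter. The expected step is a 3.8-fold lower number from compound 3 to compound 4 (0.57 log units; beyond the scatter). For compound 4 the estimate is 200 nM, with a range from 50 nM to 800 nM.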

Compound 4, half-maximal inhibitory concentration: 38 nM
Estimate against measurement, compound 4: 5.3-fold (0.72 log units) above, outside the stated range (below it).
By their numbers in this assay, from the lowest: compounds 1, 4 and 2 (each within the scatter of the next); then compound 3.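

In this assay, 3,5-dimethylphenyl in place of 4-methylphenyl on this aromatic carbon of the shared core gives a 20-fold lower number from compound 3 to compound 4 (1.30 log units; beyond the scatter), so methyl groups on this ring do not by themselves go with weak inhibition; the weak result of compound 3 is tied to the 4-methylphenyl pattern. The remaining comparisons, a 1.1-fold lower number from compound 2 to compound 4 (0.03 log units; within the scatter) and no change at the digits printed from compound 1 to compound 4 (within the scatter), show that compound 4 cannot be told apart from compound 1 or compound 2, which leaves 4-methylphenyl as the only one of the four aryl groups that stands apart at this position. Nothing available here explains why this one group differs from the other three.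

From the compounds shown here alone, it remains open whether 3-methylphenyl, with its single methyl, would match 3,5-dimethylphenyl, which would show whether one methyl in that ring placement is enough. Going by these compounds, it is also open whether 4-chlorophenyl or 4-methoxyphenyl at the same place would give a number close to that of compound 3 or close to that of compound 1.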